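From 3-chlorophenyl to 2-chlorophenyl in compound 2

The source may hold more compounds than are shown below. What is called first, only, known or untested is meant among the compounds shown, and "the series" means these compounds.

This account concerns two measured compounds, compound 1 (`CNC(=O)c1cc(C(=O)N[C@H]2CC[C@H](O)CC2)n([C@@H](C)c2cccc(Cl)c2)n1`) and compound 2 (`CNC(=O)c1cc(C(=O)N[C@H]2CC[C@H](O)CC2)c([C@@H](C)c2cccc(Cl)c2)o1`), and one still unmeasured, compound 3 (`CNC(=O)c1cc(C(=O)N[C@H]2CC[C@H](O)CC2)c([C@@H](C)c2ccccc2Cl)o1`), all followed in a physicochemical assay for solubility, measured as kinetic solubility; on this read-out higher numbers stand for higher solubility and lower numbers for lower solubility. Compound 1 gives >= 143 ug/mL, and this value is a limit of the assay. Compound 2 gives >= 179 ug/mL, which is likewise a limit and not a number. Going by the values given here, compound 2 therefore has no exact standing, and the only other value available is also a limit, so the two cannot be placed in order.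

The change from compound 2 to compound 3 is 2-chlorophenyl in place of 3-chlorophenyl on a saturated chain carbon bound to an aromatic carbon and a saturated chain carbon. It puts 2-chlorophenyl in place of 3-chlorophenyl on a saturated chain carbon bound to an aromatic carbon and a saturated chain carbon, and the two compounds have the same atoms, joined differently. Among the compounds with values here, no measured step shows what such a change does, so no shift beyond the usual scatter is expected in this assay. The estimate starts from compound 2, whose limit is >= 179 ug/mL. The expected step of an at least 1.0-fold lower number from compound 2 to compound 3 (0.02 log units; that floor lies within the scatter) is small and has no firm direction. For compound 3 the estimated value is 170 ug/mL, with an expected range from 90 ug/mL to 210 ug/mL.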

Compound 3, solubility: >= 242 ug/mL
Compound 3: no number, only a limit (the forecaster's own chance of this, stated with the estimate: 65%); middle value at least 1.4-fold (0.15 log units) away from the limit.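

In this assay compound 3 gives >= 242 ug/mL, which is a limit and not a number. Compound 2 also stands only at a limit, so the step from one to the other cannot be read. The compounds shown leave open whether 2-chlorophenyl and 3-chlorophenyl differ at all in this assay, and where the actual values lie.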